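Swapping a methyl on the least stable compound

A few compounds are considered here, and "the series" means these few. Any claim that something is new, unique, unknown or untested is made for them only; others in the source may bear on it.

Measured in an ADME assay on microsomes from liver (Rattus norvegicus) for metabolic stability, with a stated time of 60 min, tested at 1 uM; on this read-out lower numbers stand for a less stable compound and higher numbers for a more stable compound:
compound 1 `COc1cc(-c2cnn3cc(OC)c(-c4cc(C)no4)nc23)ccn1`: 62%
compound 2 `COc1cc(-c2cnn3cc(OC)c(C)nc23)ccn1`: 13%
compound 3 `Cn1cc(-c2nc3c(-c4ccnc(OC5CC5)c4)cnn3cc2OCCCC(C)(C)O)cn1`: 64%

Compound 2 has the lowest number of the three, and both others lie beyond the usual scatter from it. Compound 4 `COc1cc(-c2cnn3cc(OC)c([C@H]4COC(C)(C)C4)nc23)ccn1` keeps the core of compound 2 and alters one place: a group of 7 heavy atoms (6 carbon, 1 oxygen; one five-membered non-aromatic ring with 1 hetero atom) in place of one carbon atom, on an aromatic carbon. For the measured compounds named here, one measured step touches that same place: a number 49 percentage points lower from compound 1 to compound 2 (beyond the scatter), a large one. Read backwards, it links a bigger group there with a higher number. The entering group here is a different one, so this single step is only a rough guide, and a rise of smaller size is expected in this assay. The estimated change is a number 27 percentage points higher from compound 2 to compound 4 (beyond the scatter). For compound 4 the expected value is 40%, within an estimated range of 15% to 70%.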

Compound 4, percent of the compound remaining: 30%
Compound 4: the middle estimate sits 10 percentage points above what was measured, within the range that was stated.
By their numbers in this assay, from the lowest: compound 2; then compound 4; then compounds 1 and 3 (each within the scatter of the next).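

In this assay, the step of a number 17 percentage points higher from compound 2 to compound 4 (beyond the scatter) adds a second case in which a larger group on this aromatic carbon goes with a higher number than methyl does. Size alone does not set the number, though: the step of a number 32 percentage points lower from compound 1 to compound 4 (beyond the scatter) separates two groups of similar heavy-atom count, one a five-membered aromatic ring and the other a non-aromatic one. No measurement here explains this difference.

On these data alone, how an amine or a longer carbon chain would read at this place remains open. So does the effect of reversing the defined stereocentre in compound 4.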